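The source may hold more compounds than are shown below. What is called first, only, known or untested is meant among the compounds shown, and "the series" means these compounds.

Working notes on the series in a functional assay on M14 cells (Homo sapiens) for cytotoxicity, read by resazurin assay, with a stated time of 72 h; a higher number here means a weaker inhibitor, a lower number a stronger inhibitor. Within the data shown here, compound 1 `COc1cc(/C=C/C(=O)OCCCCOc2no[n+]([O-])c2S(=O)(=O)c2ccccc2)ccc1O` gives 400 nM, the only true number so far. Compound 2 `O=C(/C=C/c1ccc(OCCCCO[N+](=O)[O-])c(O)c1)OCCCCO[N+](=O)[O-]` also carries a hydroxy on the aromatic ring, and its > 50000 nM is a limit of the assay. Compound 3 `COc1cc(/C=C/C(=O)OCCCO[N+](=O)[O-])ccc1OCCCO[N+](=O)[O-]` reads > 50000 nM, likewise a limit and not a number. Compound 3 therefore stands at the limit of > 50000 nM in this assay, at which 2 of the 3 values shown sit.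

Compound 4 `COc1cc(/C=C/C(=O)OCCCO[N+](=O)[O-])ccc1O` differs from compound 3 by hydrogen in place of 3-(nitrooxy)propyl on an oxygen on an aromatic ring, with hydrogen in place of 3-(nitrooxy)propyl on an oxygen on an aromatic ring. The expected outcome in this assay is no change beyond the scatter, as the hydroxy of compound 2 brought no measurable value. The estimated change is a number no higher from compound 3 to compound 4 (the limit leaves the size open). For compound 4 the expected value is 50000 nM, with an estimated range of 20000 nM to 100000 nM.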

Compound 4, half-maximal inhibitory concentration: 42600 nM
The estimate for compound 4 lay 1.2-fold (0.07 log units) above the measured number; low and high end bracket the measured number.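

In this assay, among these compounds, compound 4 gives 42600 nM, the first true number for a compound with hydroxy at this position on the ring. Hydrogen in place of 3-(nitrooxy)propyl on that oxygen gives an at least 1.1-fold lower number from compound 3 to compound 4 (0.06 log units; that floor lies within the scatter), so no real change can be claimed. The value of compound 3 is a limit and not a number, leaving the size of the step open: the limit of > 50000 nM in this assay, at which 2 of the 4 values shown sit.

Going by these compounds, whether an amine, a carboxylic acid or a longer chain on that oxygen would move the number remains open. So does which single change separates the shared core of compound 4 from compound 1.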